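A few compounds are considered here, and "the series" means these few. Any claim that something is new, unique, unknown or untested is made for them only; others in the source may bear on it.

In a functional assay on blood (Homo sapiens), with a stated time of 60 min, in the presence of a further agent that is not named here (a higher number here means that more compound is needed for the effect, a lower number that less compound is needed), compound 3 `CS(=O)(=O)NC(=O)C1(S(=O)(=O)c2ccc(Oc3ccc(OC(F)(F)F)cc3)cc2)CCC2(CCNCC2)C1` gives > 15000 nM, which is a limit of the assay and not a number. Compound 2 `O=C(Nc1nccs1)C1(S(=O)(=O)c2ccc(Oc3ccc(OC(F)(F)F)cc3)cc2)CCC2(CCNCC2)C1` also reads as a limit, at > 15000 nM. Together they make up (the limit of > 15000 nM in this assay, at which 2 of the 3 values shown sit). Only compound 1 `CON(C)C(=O)C1(S(=O)(=O)c2ccc(Oc3ccc(OC(F)(F)F)cc3)cc2)CCC2(CCNCC2)C1` has a true number, 3700 nM.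

The next compound, compound 4 `COc1ccc(N)c(NC(=O)C2(S(=O)(=O)c3ccc(Oc4ccc(OC(F)(F)F)cc4)cc3)CCC3(CCNCC3)C2)c1`, keeps the shared core and changes only the group on the amide-type nitrogen, with 2-amino-5-methoxyphenyl in place of methylsulfonyl on an amide-type nitrogen.

Going by the values given here, no measured step makes this exact change, so the evidence is indirect. Swapping the group on the carbonyl carbon gave an at least 4.0-fold higher number from compound 1 to compound 2 (0.60 log units; beyond the scatter) and also an at least 4.0-fold higher number from compound 1 to compound 3 (0.60 log units; beyond the scatter). Both steps lead towards needing more compound, and their true sizes remain hidden behind the limit. The comparison of the two limited compounds gives a step that the two limits leave unreadable from compound 2 to compound 3, so it offers no guide to how much the group on that nitrogen matters. Among the compounds with values here, compound 2 is the nearest precedent, since it also carries a ring on that nitrogen, and its value of > 15000 nM is again a limit.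

Compound 4 is therefore expected to stay near the limit, with no clear move in either direction. The estimated step is a number no higher from compound 3 to compound 4 (the limit leaves the size open). For compound 4 the estimated value is 15000 nM, with an expected range from 4000 nM to 45000 nM.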

Compound 4, half-maximal effective concentration: 3700 nM
Compound 4: the middle estimate sits 4.1-fold (0.61 log units) above what was measured; measured number outside the range, below it.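

In this assay the group on the amide-type nitrogen clearly matters: 2-amino-5-methoxyphenyl gives an at least 4.0-fold lower number from compound 3 to compound 4 (0.60 log units; beyond the scatter) when it replaces methylsulfonyl, and an at least 4.0-fold lower number from compound 2 to compound 4 (0.60 log units; beyond the scatter) when it replaces 1,3-thiazol-2-yl. A ring on that nitrogen does not by itself decide the outcome, as compound 2 and compound 4 both carry one, yet only compound 4 has a true number. The (2-amino-5-methoxyphenyl)amino group also gives no change at the digits printed from compound 1 to compound 4 (within the scatter) when it replaces methoxy(methyl)amino, while the true sizes of the two lower steps, and the step between compound 2 and compound 3, cannot be read because both compounds sit at a limit: the limit of > 15000 nM in this assay, at which 2 of the 4 values shown sit.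

The compounds shown do not separate the contribution of the amino group from that of the methoxy group on the new ring. A plain phenyl group on that nitrogen, or a ring carrying a carboxylic acid in place of the amino group, would test in this assay whether the amine, the methoxy group or the ring alone accounts for the true number.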